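Compound 4: cyclopropylsulfonyl variant of compound 1

This account rests on a few compounds, and the source may have more. Where it says the series, first, only, none or still open, it means among the compounds named here.

Compound 1 `CN1CCN(c2ccc(C3=NN(C(=O)CCCl)C(c4ccc(N(C)C)cc4)C3)cc2)CC1` gives 1.7% in a functional assay on HCC1806 cells (Homo sapiens) for inhibition, read by sulforhodamine B assay, tested at 10 uM (a higher number here means more inhibition at the concentration tested (going by the name of the read-out), a lower number less inhibition), the second highest of the three numbers measured. Compound 2 `COC(=O)CC(=O)N1N=C(c2ccc(N3CCN(C)CC3)cc2)CC1c1ccc(N(C)C)cc1` gives -8.3%, and the step of a number 10 percentage points lower from compound 1 to compound 2 (within the scatter) lies within the scatter. Compound 3 `CN1CCN(c2ccc(C3=NN(C(=O)/C=C/c4ccccc4)C(c4ccc(N(C)C)cc4)C3)cc2)CC1` gives 71%, and the step of a number 69.3 percentage points higher from compound 1 to compound 3 (beyond the scatter) is large. Compound 4 `CN1CCN(c2ccc(C3=NN(S(=O)(=O)C4CC4)C(c4ccc(N(C)C)cc4)C3)cc2)CC1` carries the change (cyclopropylsulfonyl in place of (2-chloroethyl)carbonyl on an amine nitrogen in a ring). Going by the values given here, no measured step removes the carbonyl; the two steps from compound 1 only exchange what sits on it, one flat, the other large with 2-phenylethenyl entering. Cyclopropylsulfonyl resembles neither, so for compound 4 a step of a number 6.3 percentage points higher from compound 1 to compound 4 (within the scatter) in this assay is expected, not beyond the scatter. The estimate for compound 4 is 8%, between -12% and 35%.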

Compound 4, a percentage reported as inhibition, at one concentration (the size of the read-out at that concentration, not a potency): 4.7%
For compound 4 the middle estimate is 3.3 percentage points above the measured one, and the stated range covers the measured number.
By their numbers in this assay, from the lowest: compounds 2, 1 and 4 (each within the scatter of the next, the first and the last beyond it); then compound 3.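

Cyclopropylsulfonyl on the ring nitrogen gives a number 3 percentage points higher from compound 1 to compound 4 (within the scatter) in this assay and so shows that exchanging the carbonyl itself for a sulfonyl, the one change here that removes it, leaves the number at the level of compound 1. The other two steps differ in size, with a number 13 percentage points higher from compound 2 to compound 4 (beyond the scatter) as a modest step and a number 66.3 percentage points lower from compound 3 to compound 4 (beyond the scatter) as a large one, which leaves compound 3 alone at the high end of the four compounds. No measurement on hand explains these differences.

Going by these compounds, whether the number of compound 3 needs the carbonyl or only the 2-phenylethenyl group stays open. A phenyl or 2-phenylethenyl group on the sulfonyl would separate the two.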